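Amine substituent changes and maximal cAMP response

A few compounds are considered here, and "the series" means these few. Any claim that something is new, unique, unknown or untested is made for them only; others in the source may bear on it.

Measured compounds:
compound 1: `CCCS(=O)(=O)N1CC=C(c2ccc3c(c2)CC(C2CCN(Cc4ccccc4)CC2)O3)CC1` — 88%
compound 2: `CCCS(=O)(=O)N1CC=C(c2ccc3c(c2)CC(C2CCN(C(=O)OC(C)C)CC2)O3)CC1` — 61%

In a functional assay on HEK293 cells with Glucose-dependent insulinotropic receptor (Homo sapiens) as the target, read by cAMP accumulation, with a stated time of 60 min (a higher number here means a larger maximal response, a lower number a smaller maximal response), compound 1 gives 88%, while compound 2 gives 61%. Among the measured compounds shown here, compound 2 stands lowest of the two numbers; its nearest neighbour is compound 1, and the single measured step, a number 27 percentage points lower from compound 1 to compound 2 (beyond the scatter), is the only comparison so far.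

Compound 3 is `CCCc1cnc(N2CCC(C3Cc4cc(C5=CCN(S(=O)(=O)CCC)CC5)ccc4O3)CC2)nc1`. It differs from compound 2 in one place: 5-propylpyrimidin-2-yl in place of isopropoxycarbonyl on an amine nitrogen in a ring. The step that bears on this is a number 27 percentage points lower from compound 1 to compound 2 (beyond the scatter), in which isopropoxycarbonyl replaced benzyl on the same ring nitrogen and the response fell by a modest amount beyond the scatter. Compound 3 removes that isopropoxycarbonyl again, so the expected step, a number 19 percentage points higher from compound 2 to compound 3 (beyond the scatter), is upward in this assay and of a size similar to the earlier fall. Compound 3 is therefore estimated at 80%, within a range of 62% to 98%.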

Compound 3, largest response reached (Emax), in percent of the reference or control that the assay uses: 107%
The estimate for compound 3 lay 27 percentage points below the measured number; the measured number lies above the stated range.
By their numbers in this assay, from the lowest: compound 2; then compound 1; then compound 3.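

Changing the group on this amine nitrogen in a ring moves the maximal response in this assay over a wider span than the first pair showed (a number 46 percentage points higher from compound 2 to compound 3 (beyond the scatter)). 5-Propylpyrimidin-2-yl also exceeds benzyl (a number 19 percentage points higher from compound 1 to compound 3 (beyond the scatter)), so the isopropoxycarbonyl result does not mark the only difference at this position, and compound 3 stands highest of the three. Among these three compounds, both groups that contain a ring stand above isopropoxycarbonyl, which has none, but nothing available accounts for the rise.

The compounds shown do not separate the contribution of the pyrimidine ring from that of its propyl chain. From the compounds shown here alone, an unsubstituted pyrimidin-2-yl group, a pyridin-2-yl group or a longer chain on the pyrimidine would bear on this, and the effect of each on the response remains open.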